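The source may hold more compounds than are shown below. What is called first, only, known or untested is meant among the compounds shown, and "the series" means these compounds.

Three anilides of one fatty acyl chain have been measured so far. In an assay on microsomes from intestine for inhibition of acyl-CoA:cholesterol acyltransferase (Oryctolagus cuniculus) (a lower number here means a stronger inhibitor, a higher number a weaker inhibitor), compound 1 `CCCCCCCC/C=C/CCCCCCCC(=O)Nc1ccc(OC)cc1OC` gives 3000 nM. Compound 2 `CCCCCCCC/C=C/CCCCCCCC(=O)Nc1ccc(F)cc1F` gives 32000 nM in this assay, which is an 11-fold higher number from compound 1 to compound 2 (1.03 log units; beyond the scatter). Compound 3 `CCCCCCCC/C=C/CCCCCCCC(=O)Nc1c(C)cccc1OC` gives 20 nM in this assay, the lowest number of the three; this amounts to a 150-fold lower number from compound 1 to compound 3 (2.18 log units; beyond the scatter) and to a 1600-fold lower number from compound 2 to compound 3 (3.20 log units; beyond the scatter). The next compound, compound 4 `CCCCCCCC/C=C/CCCCCCCC(=O)Nc1c(C)cccc1OCC`, differs from compound 3 by methyl in place of hydrogen on a saturated chain carbon bound to an oxygen on an aromatic ring. Going by the values given here, none of the measured steps touches this position; each of them swaps the whole set of groups on the aryl ring, and each was large, so the aryl side of the amide is clearly sensitive to what sits on it, but a change within the methoxy group itself has no precedent here. With no direct comparison, only a modest step is expected in this assay, in either direction, and the estimate is kept close to compound 3. Compound 4 is expected to give 30 nM in this assay, within 8 nM to 120 nM. The step expected is a 1.5-fold higher number from compound 3 to compound 4 (0.18 log units; within the scatter).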

Compound 4, half-maximal inhibitory concentration: 15 nM
Beside the measured number, compound 4's estimate is 2.0-fold (0.30 log units) above it, within the range that was stated.
By their numbers in this assay, from the lowest: compounds 4 and 3 (each within the scatter of the next); then compound 1; then compound 2.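

Methyl in place of hydrogen on a saturated chain carbon bound to an oxygen on an aromatic ring, methoxy to ethoxy, is the first edit made inside this group, and in this assay it reads as a 1.3-fold lower number from compound 3 to compound 4 (0.12 log units; within the scatter), so compound 3 and compound 4 cannot be told apart. Swaps of the whole aryl group remain large with the ethoxy group in place, at a 2100-fold lower number from compound 2 to compound 4 (3.33 log units; beyond the scatter) and a 200-fold lower number from compound 1 to compound 4 (2.30 log units; beyond the scatter). No measured evidence bears on this result.

Going by these compounds, whether a propoxy or benzyloxy group in place of ethoxy would stay level with these two compounds remains open. On these data alone, the separate contributions of the methyl group and the alkoxy group also remain open, as every step to compound 1 or compound 2 swaps the aryl group whole.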